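Urea to Amide on a Shared Pyrazole Core

The source may report more compounds than this note shows. Statements on the series, on what has been measured and on what is new or still open speak of the compounds shown alone.

Compound 1: `COc1cc(-c2nn(-c3cccc(NC(=O)c4cccc(C(F)(F)F)c4)c3)cc2-c2ccncc2)ccc1Cl` gives 1400 nM in a functional assay on K562 cells (Homo sapiens) for inhibition, read by sulforhodamine B assay, with a stated time of 48 h; on this read-out lower numbers stand for stronger inhibition of growth and higher numbers for weaker inhibition of growth.
Compound 2: `COc1cc(-c2nn(-c3cccc(NC(=O)Nc4ccc(Cl)c(Cl)c4)c3)cc2-c2ccncc2)ccc1Cl` gives 890 nM in this assay.
Compound 3: `COc1cc(-c2nn(-c3cccc(NC(=O)Nc4cccc(C(F)(F)F)c4)c3)cc2-c2ccncc2)ccc1Cl` gives 584 nM in this assay.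

Compound 3 has the lowest number of the three. Its nearest neighbour is compound 2, and the difference is a 1.5-fold lower number from compound 2 to compound 3 (0.18 log units; within the scatter), which does not let one call compound 3 the most potent. Against compound 1 the gap is a 2.4-fold lower number from compound 1 to compound 3 (0.38 log units; beyond the scatter).

Compound 4, `COc1cc(-c2nn(-c3cccc(NC(=O)c4ccc(Cl)c(C(F)(F)F)c4)c3)cc2-c2ccncc2)ccc1Cl`, is not yet measured. It differs from compound 3 by 4-chloro-3-(trifluoromethyl)phenyl in place of (3-(trifluoromethyl)phenyl)amino on a carbonyl carbon. For the measured compounds named here, the step that bears most directly on this is the one from compound 1 to compound 3, a 2.4-fold lower number from compound 1 to compound 3 (0.38 log units; beyond the scatter), where the same kind of change ran the other way; compound 4 reverses it while also carrying a chlorine on the ring. The step from compound 1 to compound 2, a 1.6-fold lower number from compound 1 to compound 2 (0.20 log units; within the scatter), shows that adding chlorine alongside a change of linker moved the number only a little. Compound 4 is therefore expected to sit closer to compound 1 than to compound 3, with an estimated step of a 2.1-fold higher number from compound 3 to compound 4 (0.31 log units; beyond the scatter). The estimate for compound 4 in this assay is 1200 nM, between 500 nM and 3000 nM.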

Compound 4, concentration for 50% growth inhibition: 1610 nM
For compound 4 the middle estimate is 1.3-fold (0.13 log units) below the measured one, within the range that was stated.
By their numbers in this assay, from the lowest: compounds 3, 2, 1 and 4 (each within the scatter of the next, the first and the last beyond it).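

In this assay, chloro in place of hydrogen on an aromatic carbon stays within the scatter (a 1.2-fold higher number from compound 1 to compound 4 (0.06 log units; within the scatter)), so on the amide this chlorine gives no difference that the read-out can separate. The gap between the amide and the urea bearing (3-(trifluoromethyl)phenyl)amino on the carbonyl carbon now appears with and without the chlorine, beyond the scatter both times (a 2.4-fold lower number from compound 1 to compound 3 (0.38 log units; beyond the scatter); a 2.8-fold higher number from compound 3 to compound 4 (0.44 log units; beyond the scatter)). The other urea goes against any general urea-over-amide reading, since its step to the chlorinated amide stays within the scatter (a 1.8-fold higher number from compound 2 to compound 4 (0.26 log units; within the scatter)), and the separation therefore holds only for compound 3.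

The data offer no measurement that would explain any of these steps. From the compounds shown here alone, it remains open whether a urea carrying the 4-chloro-3-(trifluoromethyl)phenyl group would stand with compound 3, and whether a methyl or methoxy group in place of the chloro, or a sulfonamide in place of the amide, would separate from compound 1.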